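Shifting the chlorine on the shared core: compound 2 to 4

The compounds below may be only part of what the source reports. "The series", "measured", "known", "first", "only" and "open" are said of these compounds alone.

Three compounds share one core, each measured in an ADME assay on HEK293 cells (Homo sapiens) for cytotoxicity, read by CCK-8 assay and cell counting, with a stated time of 2 days; a lower number here means a stronger inhibitor, a higher number a weaker inhibitor. Compound 2 `Oc1ccc(-c2cc(-c3ccccc3)nc(-c3ccccc3Cl)c2)cc1` gives 3930 nM, and among the numbers reported it stands as the lower of two. Compound 3 `Oc1ccc(-c2cc(-c3ccsc3)nc(-c3ccccc3Cl)c2)cc1` gives 5930 nM, and the step of a 1.5-fold higher number from compound 2 to compound 3 (0.18 log units; within the scatter) does not separate the two. Compound 1 `Oc1ccc(-c2cc(-c3cccnc3)nc(-c3ccccc3Cl)c2)cc1` has no number, its entry reading "not determined" (no result reported).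

Compound 4 `Oc1ccc(-c2cc(-c3ccccc3)nc(-c3ccc(Cl)cc3)c2)cc1` has the same atoms as compound 2, joined differently: 4-chlorophenyl in place of 2-chlorophenyl on an aromatic carbon. The exchanged group sits on an aromatic carbon of a six-membered aromatic ring with 1 nitrogen.

For the measured compounds named here, no measured step touches this exchange. Going by the values given here, the only step on record, from compound 2 to compound 3, concerns a different group and stayed within the scatter. The expected step is a 1.0-fold higher number from compound 2 to compound 4 (0.01 log units; within the scatter), meaning nothing beyond the scatter. Compound 4 is therefore estimated to give 4000 nM, with a range from 1500 nM to 11000 nM.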

Compound 4, half-maximal inhibitory concentration: 4810 nM
Estimate against measurement, compound 4: 1.2-fold (0.08 log units) below, within the range that was stated.
By their numbers in this assay, from the lowest: compounds 2, 4 and 3 (each within the scatter of the next).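

Moving the chlorine from the 2-chlorophenyl to the 4-chlorophenyl arrangement, on the aromatic carbon next to the ring nitrogen, gives a 1.2-fold higher number from compound 2 to compound 4 (0.09 log units; within the scatter) in this assay, so these two placements cannot be told apart. For the compounds shown here, the earlier step changed only the group on the other side of the shared core, whereas this pair gives the first reading on the chlorophenyl group itself: here, the chlorine's location on that ring leaves no difference that can be read in this cell test. No measured evidence bears on why the two compounds read alike.

Every compound shown carries a chlorine on this ring, so what the chlorine itself contributes remains open. Also open, as far as these compounds go, is whether an amine or a carboxylic acid in its place would give a step beyond the scatter.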